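Changing One Sulfur Substituent in a Poorly Soluble Series

The compounds below may be only part of what the source reports. "The series", "measured", "known", "first", "only" and "open" are said of these compounds alone.

Of the compounds shown here, two that share one core have been tested in a physicochemical assay for solubility, read by nephelometry, in phosphate buffer, measured as kinetic solubility, at pH 6.5; a higher number here means a more soluble compound, a lower number a less soluble compound. Compound 1 (`CCOC(=O)C1=C(C)N/C(=C/c2cc(C)n(-c3cccc(OC)c3)c2C)C1=O`) gives < 1.6 ug/mL, and this reading is a limit of the assay, not a number. Within the data shown here, compound 2 (`CCOC(=O)C1=C(C)N/C(=C/c2cc(C)n(-c3ccc(SC(F)(F)F)cc3)c2C)C1=O`) gives 1 ug/mL, which is the only true number available so far.

Compound 3 (`CCOC(=O)C1=C(C)N/C(=C/c2cc(C)n(-c3ccc(SC)cc3)c2C)C1=O`) has not yet been measured. It differs from compound 2 in a single place, with methyl in place of trifluoromethyl on a sulfur. Among the measured compounds shown here, no measured pair of compounds shows what this exchange does, so there is no direct precedent to lean on. The starting point is therefore compound 2 at 1 ug/mL, and no shift beyond the usual scatter is expected in this assay. The expected step is a 1.4-fold higher number from compound 2 to compound 3 (0.15 log units; within the scatter), and it should stay within the scatter of repeated measurements. The estimate for compound 3 is 1.4 ug/mL, with an expected range of 0.6 ug/mL to 3.5 ug/mL. The assay could also return only a limit for this compound, and not a number.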

Compound 3, solubility: 1.6 ug/mL
Beside the measured number, compound 3's estimate is 1.1-fold (0.06 log units) below it; measured number inside the range.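

In this assay, among these compounds, this is the first direct look at what happens when methyl takes the place of trifluoromethyl on a sulfur whose other neighbour is an aromatic carbon, and the result is a 1.6-fold higher number from compound 2 to compound 3 (0.20 log units; within the scatter). The step lies within the scatter, so compound 2 and compound 3 cannot be told apart here, and this exchange on the sulfur shows no effect that repeated measurements could separate from noise. With 4-(methylsulfanyl)phenyl in place of 3-methoxyphenyl on an aromatic nitrogen, the reading is a number no lower from compound 1 to compound 3 (the limit leaves the size open) and no more can be said of this step. The reading for compound 1 is a limit and not a number, and one reading of the set remains without a true size: the limit of < 1.6 ug/mL in this assay, at which 1 of the 3 values shown sits.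

The compounds shown leave open whether any other group at this place, such as an amine or a carboxylic acid in place of the methylsulfanyl group, would shift the reading beyond the scatter. Among the compounds shown here, they also leave open whether the exchange of methyl for trifluoromethyl on a sulfur would stay this small on a different core, since only one pair shows it.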